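Swapping the aryl amide cap: methoxy to fluoro

A few compounds are considered here, and "the series" means these few. Any claim that something is new, unique, unknown or untested is made for them only; others in the source may bear on it.

Measured compounds:
- Compound 1, `CN(C)C(=O)c1cc2cnc(Nc3ccc(NC(=O)C4(C(=O)Nc5cccc(Br)c5)CC4)cc3)nc2n1C1CCCC1`: 92.2%
- Compound 2, `COc1cccc(NC(=O)C2(C(=O)Nc3ccc(Nc4ncc5cc(C(=O)N(C)C)n(C6CCCC6)c5n4)cc3)CC2)c1`: 96%

Both compounds were tested in a functional assay on A549 cells (Homo sapiens) for inhibition, read by CCK-8 assay, with a stated time of 72 h, tested at 10 uM; on this read-out lower numbers stand for less inhibition of growth and higher numbers for more inhibition of growth at the one concentration tested. The step between them is a number 3.8 percentage points higher from compound 1 to compound 2 (within the scatter), so the two are not distinguishable on this read-out. The change in that step was methoxy in place of bromo on an aromatic carbon.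

Compound 3, `CN(C)C(=O)c1cc2cnc(Nc3ccc(NC(=O)C4(C(=O)Nc5ccc(F)cc5)CC4)cc3)nc2n1C1CCCC1`, has not yet been measured. It differs from compound 2 by 4-fluorophenyl in place of 3-methoxyphenyl on an amide-type nitrogen. Going by the values given here, no measured step touches this particular exchange; the only step available, from bromo to methoxy, left the number essentially unchanged, and both measured compounds sit near the top of the scale. With nothing pointing to a change beyond the scatter, compound 3 is expected to stay high in this assay, with the step of a number 5 percentage points lower from compound 2 to compound 3 (within the scatter) being small. The estimate for compound 3 is 91%, within a range from 76% to 98%.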

Compound 3, percent growth inhibition at one concentration: 102%
Compound 3: the middle estimate sits 11 percentage points below what was measured; the measured number lies above the stated range.
By their numbers in this assay, from the lowest: compounds 1, 2 and 3 (each within the scatter of the next).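

In this assay the exchange of 3-methoxyphenyl for 4-fluorophenyl on the amide-type nitrogen gives a number 6 percentage points higher from compound 2 to compound 3 (within the scatter) and the exchange of 3-bromophenyl for 4-fluorophenyl gives a number 9.8 percentage points higher from compound 1 to compound 3 (within the scatter) so the three compounds cannot be told apart on this read-out. Going by these compounds alone, the earlier pair compared only two 3-substituted phenyl groups, whereas this result adds a 4-substituted ring with a different substituent, and growth inhibition stays near the top of the scale, with compound 3 at 102% in this single-concentration test. Nothing shown here accounts for how well this position accepts these exchanges.

From the compounds shown here alone, all three compounds carry a substituted phenyl ring at this position, so it remains open whether an aromatic ring is needed there at all, and a cyclohexyl group or a phenyl ring bearing a carboxylic acid or a dimethylamino group would test that. Going by these compounds, it also remains open whether the three would separate at lower concentrations, where their numbers would no longer sit so close to the top of the scale.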